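A few compounds are considered here, and "the series" means these few. Any claim that something is new, unique, unknown or untested is made for them only; others in the source may bear on it.

Measured compounds in this series:

- compound 1, `CCC(CC)C(=O)OCC1CN(C(=O)c2cc(OC)c(OC)c(OC)c2)CCN1C(=O)c1cc(OC)c(OC)c(OC)c1`: 70 nM; 40 nM; 60 nM (3 entries)
- compound 2, `CCCCNC(=O)OCC1CN(C(=O)c2cc(OC)c(OC)c(OC)c2)CCN1C(=O)c1cc(OC)c(OC)c(OC)c1`: 240 nM

In a functional assay (Oryctolagus cuniculus) for inhibition of platelet-activating factor receptor (Cavia porcellus) (a lower number here means a stronger inhibitor, a higher number a weaker inhibitor), compound 1 gives 70 nM; 40 nM; 60 nM (3 entries); the spread of those repeats, (the several entries of compound 1 in this assay, 70 nM; 40 nM; 60 nM (3 entries)), shows how far single readings of one compound may fall apart. Compound 2 has a single number, 240 nM, beside one further record for which no single number is given, so its place rests on that one reading; it sits at a higher number than any of the readings of compound 1 in this assay.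

The next compound, compound 3, `COc1cc(C(=O)N2CCN(C(=O)c3cc(OC)c(OC)c(OC)c3)C(COC(=O)NC(C)(C)C)C2)cc(OC)c1OC`, carries the same atoms as compound 2 arranged differently: tert-butyl in place of butyl on an amide-type nitrogen. The chain on the carbamate nitrogen becomes branched, with no change in count of atoms, donors or acceptors. Among the measured compounds shown here, no step between two measured compounds of this kind is at hand, so the expected change rests only on the small size of the rearrangement. The step from compound 2 to compound 3 is expected to be small, a 1.3-fold higher number from compound 2 to compound 3 (0.10 log units; within the scatter), and not beyond the scatter. Compound 3 is therefore estimated at 300 nM in this assay, within a range of 110 nM to 850 nM.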

Compound 3, half-maximal inhibitory concentration: 130 nM
The estimate for compound 3 lay 2.3-fold (0.36 log units) above the measured number, within the range that was stated.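

In this assay the series now has its first step at this position, tert-butyl in place of butyl on an amide-type nitrogen, and it reads as a 1.8-fold lower number from compound 2 to compound 3 (0.27 log units; within the scatter). The two chains therefore cannot be told apart in this pair, so branching at this nitrogen shows no readable effect on the number, and the value for compound 2 still rests on a single reading. Repeat readings of one compound in this assay fall apart by a similar margin, which makes the step no firmer than the repeats themselves: the several entries of compound 1 in this assay, 70 nM; 40 nM; 60 nM (3 entries).

The compounds shown leave open how a longer chain such as octyl, a ring such as cyclohexyl or phenyl, or a chain ending in an amine or a carboxylic acid would read on this nitrogen. Also open is what the carbamate nitrogen itself contributes, as no pair shown changes it alone.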